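The source may report more compounds than this note shows. Statements on the series, on what has been measured and on what is new or still open speak of the compounds shown alone.

Of the compounds shown here, three built on one shared core have been measured in a functional assay on MDA-MB-231 cells (Homo sapiens) for inhibition, read by MTT assay, with a stated time of 24 h, tested at 100 uM; a lower number here means less inhibition, a higher number more inhibition at the concentration tested (going by the name of the read-out). Compound 1 `COc1ccc(/C=N/NC(=O)c2ccc(O[C@@H]3O[C@H](CO)[C@@H](O)[C@H](O)[C@H]3O)cc2)cc1` carries a 4-methoxyphenyl group on a carbon with a double bond to nitrogen and gives 11.3%, the highest of the three numbers. Compound 2 `O=C(N/N=C/C1CCCCC1)c1ccc(O[C@@H]2O[C@H](CO)[C@@H](O)[C@H](O)[C@H]2O)cc1`, with cyclohexyl in that place, gives 0.88%, and compound 3 `N#Cc1cccc(/C=N/NC(=O)c2ccc(O[C@@H]3O[C@H](CO)[C@@H](O)[C@H](O)[C@H]3O)cc2)c1`, with 3-cyanophenyl there, gives 6.17%. The step of a number 10.4 percentage points lower from compound 1 to compound 2 (beyond the scatter) is the only one that reaches beyond the scatter, while a number 5.1 percentage points lower from compound 1 to compound 3 (within the scatter) and a number 5.3 percentage points higher from compound 2 to compound 3 (within the scatter) stay within it, so compound 1 and compound 3 cannot be ordered against each other.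

Compound 4 `Cc1ccc(/C=N/NC(=O)c2ccc(O[C@@H]3O[C@H](CO)[C@@H](O)[C@H](O)[C@H]3O)cc2)cc1` has not yet been measured in this assay. It differs from compound 1 by methyl in place of methoxy on an aromatic carbon. Going by the values given here, none of the measured steps makes exactly this change. The closest comparison, swapping one aromatic substituent for another, is a number 5.1 percentage points lower from compound 1 to compound 3 (within the scatter), which stayed within the scatter, whereas the larger change from an aromatic ring to cyclohexyl, a number 10.4 percentage points lower from compound 1 to compound 2 (beyond the scatter), was modest but beyond it. Exchanging one small group for another on the same aromatic ring is expected to move the number less than either of these. Compound 4 is therefore expected to give 9%, within 0% to 20%, an expected step of a number 2.3 percentage points lower from compound 1 to compound 4 (within the scatter) that stays within the scatter.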

Compound 4, a percentage reported as inhibition, at one concentration (the size of the read-out at that concentration, not a potency): 9.28%
Beside the measured number, compound 4's estimate is 0.3 percentage points below it, and the stated range covers the measured number.
By their numbers in this assay, from the lowest: compounds 2, 3, 4 and 1 (each within the scatter of the next, the first and the last beyond it).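

In this assay, methyl in place of methoxy on an aromatic carbon, para to a large group, gives a number 2 percentage points lower from compound 1 to compound 4 (within the scatter) and so removes one heavy atom and one hydrogen-bond acceptor without a difference this read-out can resolve. The other two new steps, a number 3.1 percentage points higher from compound 3 to compound 4 (within the scatter) and a number 8.4 percentage points higher from compound 2 to compound 4 (within the scatter), also stay within the scatter, so compound 4 cannot be ordered against any of the other three compounds, and the separation from the cyclohexyl compound seen with the 4-methoxyphenyl group is not seen with the 4-methylphenyl group. No independent evidence is available to explain these numbers.

The compounds shown cover only methoxy and methyl at this place on the ring, so it remains open whether an amine, a carboxylic acid or a longer chain such as butoxy would give a number beyond the scatter from that of compound 1. As far as these compounds go, it also remains open whether the small differences among the aromatic compounds would hold at other concentrations, since each number here comes from one tested concentration.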